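Pyrrolidine carbamoyl amide variants of a sulfonamide binder

The compounds below may be only part of what the source reports. "The series", "measured", "known", "first", "only" and "open" are said of these compounds alone.

Measured compounds:
- compound 1, `CN(C)CC(=O)N1CCC(NS(=O)(=O)c2cc(S(=O)(=O)c3ccccc3)ccc2C(F)(F)F)CC1`: 300 nM
- compound 2, `CC(C)(C)OC(=O)N1CCC[C@@H]1C(=O)N1CCC(NS(=O)(=O)c2cc(S(=O)(=O)c3ccccc3)ccc2C(F)(F)F)CC1`: 120 nM
- compound 3, `CCNC(=O)N1CCC[C@H]1C(=O)N1CCC(NS(=O)(=O)c2cc(S(=O)(=O)c3ccccc3)ccc2C(F)(F)F)CC1`: 30 nM

All three were tested in an assay on isolated protein for binding affinity to secreted frizzled-related protein 1 (Homo sapiens), read by fluorescence; on this read-out lower numbers stand for stronger inhibition and higher numbers for weaker inhibition. On these numbers compound 1 stands highest of the three: compound 2 is nearest, and compound 3 furthest from it, both being lower.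

The unmeasured compound 4, `CC(C)(C)NC(=O)N1CCC[C@H]1C(=O)N1CCC(NS(=O)(=O)c2cc(S(=O)(=O)c3ccccc3)ccc2C(F)(F)F)CC1`, is reached from compound 1 by one change: 1-((tert-butyl)carbamoyl)pyrrolidin-2-yl in place of (dimethylamino)methyl on a carbonyl carbon. Among the compounds with values here, two measured steps bear on this. Replacing the same group with a pyrrolidine carrying a tert-butoxycarbonyl gave a 2.5-fold lower number from compound 1 to compound 2 (0.40 log units; beyond the scatter), and with a pyrrolidine carrying an ethylcarbamoyl gave a 10-fold lower number from compound 1 to compound 3 (1.00 log units; beyond the scatter). The step of a 4.0-fold lower number from compound 2 to compound 3 (0.60 log units; beyond the scatter) shows the carbamoyl variant giving the lower number. Compound 4 carries a carbamoyl like compound 3, with a larger substituent, so a lowering of a size between these two steps is expected, a 7.5-fold lower number from compound 1 to compound 4 (0.88 log units; beyond the scatter). The estimated value for compound 4 in this assay is 40 nM, with a range from 15 nM to 120 nM.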

Compound 4, half-maximal inhibitory concentration: 20 nM
Compound 4: middle estimate off by 2.0-fold (0.30 log units), on the high side; the measured number falls inside the stated range.
By their numbers in this assay, from the lowest: compounds 4 and 3 (each within the scatter of the next); then compound 2; then compound 1.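

Replacing ethyl with tert-butyl on the amide-type nitrogen gives a 1.5-fold lower number from compound 3 to compound 4 (0.18 log units; within the scatter) and so leaves the two compounds indistinguishable, which shows that this nitrogen accepts a larger group than ethyl with no change that can be read. The full replacement on the carbonyl carbon gives a 15-fold lower number from compound 1 to compound 4 (1.18 log units; beyond the scatter) as the largest step among these compounds, so a second carbamoyl variant now shows a gain over the (dimethylamino)methyl group. The tert-butylcarbamoyl also gives a 6.0-fold lower number from compound 2 to compound 4 (0.78 log units; beyond the scatter) against the tert-butoxycarbonyl, although compound 2 is drawn with the opposite configuration at the pyrrolidine stereocentre, so this step covers two differences.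

Still open, from the compounds shown here alone, is how a methyl or a cyclohexyl on that nitrogen would compare, and how a carbamoyl would fare with the opposite configuration. Nothing available explains why these groups give these numbers.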